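The compounds below may be only part of what the source reports. "The series", "measured", "known", "first", "only" and "open" are said of these compounds alone.

Three compounds share one core and differ only in a group that sits on an aromatic carbon of a six-membered aromatic ring of carbon only, ortho to a large group. Compound 1 `CC(C)(N)CC(=O)N[C@@H]1CCc2ccccc2N(Cc2ccc(-c3ccccc3C(=O)O)cc2)C1=O` carries a carboxy group there, and in a functional assay (Pituitary gland cell) with Rattus norvegicus as the target (on this read-out lower numbers stand for an effect already at smaller amounts and higher numbers for an effect only at larger amounts of compound), compound 1 gives 3 uM. Compound 2 `COC(=O)c1ccccc1-c1ccc(CN2C(=O)[C@H](NC(=O)CC(C)(C)N)CCc3ccccc32)cc1` carries a methoxycarbonyl group, and in this assay compound 2 gives 2 uM. Compound 3 `CC(C)(N)CC(=O)N[C@@H]1CCc2ccccc2N(Cc2ccc(-c3ccccc3-c3nnnn3CC(=O)O)cc2)C1=O` carries a 1-(carboxymethyl)-1H-tetrazol-5-yl group, and in this assay compound 3 gives 1 uM, the lowest of the three numbers: its gap to compound 2 is within the scatter, its gap to compound 1 beyond it. The measured steps read a 1.5-fold lower number from compound 1 to compound 2 (0.18 log units; within the scatter), a 3.0-fold lower number from compound 1 to compound 3 (0.48 log units; beyond the scatter) and a 2.0-fold lower number from compound 2 to compound 3 (0.30 log units; within the scatter).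

Compound 4 `CC(C)(N)CC(=O)N[C@@H]1CCc2ccccc2N(Cc2ccc(-c3ccccc3C(N)=O)cc2)C1=O` has not yet been measured. It differs from compound 3 in one place: carbamoyl in place of 1-(carboxymethyl)-1H-tetrazol-5-yl on an aromatic carbon. This undoes the kind of change seen in the steps from compound 1 and from compound 2 to compound 3, which lowered the number modestly or not beyond the scatter. The step is therefore expected to run the other way, a 2.5-fold higher number from compound 3 to compound 4 (0.40 log units; beyond the scatter), back toward the numbers of compounds 1 and 2. Compound 4 is expected to give about 2.5 uM, within a range from 1 uM to 7 uM.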

Compound 4, concentration for half-maximal effect: 0.08 uM
Estimate against measurement, compound 4: 31-fold (1.49 log units) above; the whole stated range lies above it.
By their numbers in this assay, from the lowest: compound 4; then compounds 3, 2 and 1 (each within the scatter of the next, the first and the last beyond it).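

Exchanging hydroxy for amino on the carbonyl carbon gives a 38-fold lower number from compound 1 to compound 4 (1.57 log units; beyond the scatter) in this assay and exchanging methoxy for amino gives a 25-fold lower number from compound 2 to compound 4 (1.40 log units; beyond the scatter) on the same read-out, so this position turns out to be far more sensitive than the first three compounds suggested. Compounds 1 and 2 also carry a carbonyl on this aromatic carbon, which shows that a carbonyl alone does not produce the low number and that the group attached to it matters, a point the earlier swap of hydrogen for methyl on the oxygen could not reveal. The larger 1-(carboxymethyl)-1H-tetrazol-5-yl group is not needed for a low number either, as a 13-fold lower number from compound 3 to compound 4 (1.10 log units; beyond the scatter) shows when carbamoyl takes its place.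

No measurement shown here explains why the amino group has so large an effect. Going by these compounds, it also remains open whether the low number would survive a methyl or a longer chain on the amide nitrogen, or a nitrile or hydroxymethyl group in place of carbamoyl on this aromatic carbon.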